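This account rests on a few compounds, and the source may have more. Where it says the series, first, only, none or still open, it means among the compounds named here.

Working notes on the series. In a functional assay on MCF7 cells (Homo sapiens) for cytotoxicity, read by MTT assay, with a stated time of 24 h (a higher number here means a weaker inhibitor, a lower number a stronger inhibitor), compound 1 `C/C(=N\NC(=O)/C(C#N)=C/c1ccc(O)cc1)c1c(O)c2ccc(O)cc2oc1=O` gives 7320 nM and compound 2 `COc1ccc(/C=C(\C#N)C(=O)N/N=C(\C)c2c(O)c3ccc(O)cc3oc2=O)cc1OC` gives 14400 nM. Within the data shown here, these are the only two numbers so far, and they lie within the scatter of each other, so compound 2 holds no real rank against compound 1.

Compound 3 `COc1ccc(/C=C(\C#N)C(=O)N/N=C(\C)c2c(O)c3ccc(O)cc3oc2=O)cc1` differs from compound 2 in one place: hydrogen in place of methoxy on an aromatic carbon. In words, hydrogen stands in place of methoxy on an aromatic carbon, which takes 3,4-dimethoxyphenyl to 4-methoxyphenyl.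

Among the measured compounds shown here, only one measured step bears on this change, and it falls on the same phenyl group: a 2.0-fold higher number from compound 1 to compound 2 (0.29 log units; within the scatter). That step replaces 4-hydroxyphenyl with 3,4-dimethoxyphenyl, so it does not isolate the methoxy group removed here. With this single step as a guide, no change beyond the scatter is expected in this assay, and the data give no firm direction.

The expected step is a 1.4-fold lower number from compound 2 to compound 3 (0.16 log units; within the scatter). Compound 3 is estimated at 10000 nM, with an expected range of 4500 nM to 23000 nM.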

Compound 3, half-maximal inhibitory concentration: 8940 nM
Beside the measured number, compound 3's estimate is 1.1-fold (0.05 log units) above it; the range from low to high includes it.
By their numbers in this assay, from the lowest: compounds 1, 3 and 2 (each within the scatter of the next).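

Hydrogen in place of methoxy on an aromatic carbon, which takes 3,4-dimethoxyphenyl to 4-methoxyphenyl, gives a 1.6-fold lower number from compound 2 to compound 3 (0.21 log units; within the scatter) in this assay and shows no readable effect of this change at this place on the ring, ortho to a methoxy group. Methyl in place of hydrogen on an oxygen on an aromatic ring gives a 1.2-fold higher number from compound 1 to compound 3 (0.09 log units; within the scatter). This separates the second change contained in the earlier step between compound 1 and compound 2, which altered the phenyl group in two ways at once; taken singly, neither change leaves the scatter, and compounds 1, 2 and 3 cannot be ranked in this assay. Nothing available explains these numbers or bears on how either group acts in the cells.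

From the compounds shown here alone, it remains open whether any substituent at this place can move the number beyond the scatter, for example an amine, a carboxylic acid or a chlorine atom in place of methoxy. Going by these compounds, a longer chain on the oxygen, such as ethoxy or propoxy in place of methoxy, is equally open.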